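Trimethoxyphenyl in Place of Isopropylphenyl on a Shared Core

This account rests on a few compounds, and the source may have more. Where it says the series, first, only, none or still open, it means among the compounds named here.

Three measured compounds share one core: compound 1 `N#Cc1c(Nc2cccc(Cl)c2)nc(SCc2cn(Cc3ccccc3Cl)nn2)nc1-c1ccccc1`, compound 2 `Cc1ccc(Nc2nc(SCc3cn(Cc4ccccc4Cl)nn3)nc(-c3ccc(C(C)C)cc3)c2C#N)cc1` and compound 3 `COc1ccc(Nc2nc(SCc3cn(Cc4ccccc4Cl)nn3)nc(-c3ccc(C(C)C)cc3)c2C#N)cc1`. In a functional assay on B16-F10 cells (Mus musculus) for inhibition, read by MTT assay, with a stated time of 72 h (a higher number here means a weaker inhibitor, a lower number a stronger inhibitor), compound 1 gives 3590 nM, compound 2 gives 3530 nM and compound 3 gives 2690 nM. Compound 2 stands second highest of these three numbers, but both of its neighbours lie within the scatter of it, so no order among the three can be read. Among the measured compounds shown here, the only step between measured compounds that differ in one place is a 1.3-fold lower number from compound 2 to compound 3 (0.12 log units; within the scatter), which alters the (4-methylphenyl)amino group rather than the aryl group that compound 4 `COc1cc(-c2nc(SCc3cn(Cc4ccccc4Cl)nn3)nc(Nc3ccc(C)cc3)c2C#N)cc(OC)c1OC` changes. Compound 4 differs from compound 2 by 3,4,5-trimethoxyphenyl in place of 4-isopropylphenyl on an aromatic carbon. For the measured compounds named here, no measured step touches this position, so the expectation rests only on the narrow span of the three numbers. For compound 4 the estimated step is a 1.2-fold lower number from compound 2 to compound 4 (0.07 log units; within the scatter), nothing beyond the scatter. Compound 4 is therefore expected to give 3000 nM in this assay, within a range from 1000 nM to 9000 nM.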

Compound 4, half-maximal inhibitory concentration: 20300 nM
Compound 4: the middle estimate sits 6.8-fold (0.83 log units) below what was measured, and the stated range ends below it.
By their numbers in this assay, from the lowest: compounds 3, 2 and 1 (each within the scatter of the next); then compound 4.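

In this assay, 3,4,5-trimethoxyphenyl in place of 4-isopropylphenyl gives a 5.8-fold higher number from compound 2 to compound 4 (0.76 log units; beyond the scatter), the first step among these compounds that lies beyond the scatter. The aryl group on this aromatic carbon, ortho to a cyano group, can therefore shift the number, which the close values of compound 1, compound 2 and compound 3 gave no sign of. Nothing available explains the shift, so it stays a bare observation tied to this one exchange.

The compounds shown leave open whether all three methoxy groups are needed for the shift or whether a single methoxy group on the phenyl ring would give it too. They also leave open how a phenyl ring bearing a carboxylic acid or an amine would read at this position.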